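This account rests on a few compounds, and the source may have more. Where it says the series, first, only, none or still open, it means among the compounds named here.

Among the measured compounds shown here, compound 1, with the structure `C[C@@H](Nc1c(C(=O)NCc2ccc(F)cc2)nc(Br)c2cccnc12)c1ccccc1`, is the only member of this small set for which a potency reading exists. In a functional assay on HCT-116 cells (Homo sapiens) for cytotoxicity, read by MTT assay, with a stated time of 72 h (a lower number here means a stronger inhibitor, a higher number a weaker inhibitor), compound 1 gives > 20000 nM, which is a limit of the assay rather than a number. Where compound 1 stands is therefore set by the limit of > 20000 nM in this assay, at which 1 of the 3 values shown sits: it is the one entry with a limit, and no single number places it more precisely. Two further compounds belong to the same series. Compound 2, with the structure `N[C@H]1CC[C@H](Nc2c(C(=O)NCc3ccccn3)nc(Br)c3cccnc23)CC1`, has "not determined" (no result reported) in this assay, and compound 3, with the structure `C[C@H](CO)Nc1nc(C(=O)NCc2ccc(F)cc2)c(O)c2ncccc12`, likewise has "not determined" (no result reported). For the measured compounds named here, neither adds a reading against which compound 1 could be compared, and no step between measured compounds can be drawn.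

Compound 4, with the structure `O=C(NCc1ccc(F)cc1)c1nc(Br)c2cccnc2c1N1CCNCC1`, has not yet been tested. It differs from compound 1 in one place: piperazin-1-yl in place of (1-phenylethyl)amino on an aromatic carbon. With only a limit for compound 1 and nothing from compound 2 or compound 3, the size of the step cannot be anchored. The expected change, expressed as an at least 1.3-fold lower number from compound 1 to compound 4 (0.12 log units; that floor lies within the scatter), is none beyond the scatter, with a real chance that this assay again reports only a limit. Compound 4 is estimated at 15000 nM, within a range from 3000 nM to 60000 nM.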

Compound 4, half-maximal inhibitory concentration: > 10000 nM
Compound 4 was reported as a limit; the forecaster's own chance of this, stated with the estimate: 55%; the middle value does not contradict the limit.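

In this assay, among the compounds shown here, compound 1 and compound 4 are each known only as a limit, and no step between them can be read. The compounds shown leave open how strongly any member of this series acts on these cells, and whether piperazin-1-yl or (1-phenylethyl)amino on that aromatic carbon gives the lower number.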